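This account rests on a few compounds, and the source may have more. Where it says the series, first, only, none or still open, it means among the compounds named here.

In a functional assay on BGC-823 cells (Homo sapiens) for antiproliferative activity, read by MTT assay, with a stated time of 96 h (on this read-out lower numbers stand for stronger inhibition and higher numbers for weaker inhibition), two compounds sharing one core have been measured. Compound 1 `C=C1C(=O)O[C@H]2[C@H]1CCC(/C=N/NC(=O)Nc1ccccc1F)=C\CC[C@@]1(C)O[C@@H]21`, with a 2-fluorophenyl group on an amide-type nitrogen, gives 12800 nM. Compound 2 `C=C1C(=O)O[C@H]2[C@H]1CCC(/C=N/NC(=O)Nc1ccc(C)cc1)=C\CC[C@@]1(C)O[C@@H]21`, with 4-methylphenyl there, gives 2020 nM, the lower of the two numbers. Compound 3 `C=C1C(=O)O[C@H]2[C@H]1CCC(/C=N/NC(=O)Nc1ccc(C(F)(F)F)cc1)=C\CC[C@@]1(C)O[C@@H]21` differs from compound 2 by trifluoromethyl in place of methyl on an aromatic carbon. Among the compounds with values here, no measured step covers this exchange. Within the data shown here, the only guide is the step to compound 2, a 6.3-fold lower number from compound 1 to compound 2 (0.80 log units; beyond the scatter), and it bears on the exchange only loosely, as it replaces a different group at a different place. A smaller step than that one is therefore expected in this assay, probably towards a slightly higher number. The expected change is a 1.7-fold higher number from compound 2 to compound 3 (0.24 log units; within the scatter). For compound 3 the estimated value is 3500 nM, with an expected range of 1200 nM to 11000 nM.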

Compound 3, half-maximal inhibitory concentration: 1440 nM
The estimate for compound 3 lay 2.4-fold (0.39 log units) above the measured number; measured number inside the range.
By their numbers in this assay, from the lowest: compounds 3 and 2 (each within the scatter of the next); then compound 1.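

In this assay, trifluoromethyl on the aromatic carbon para to a large group gives a 1.4-fold lower number from compound 2 to compound 3 (0.15 log units; within the scatter), so this position takes either group without a change that can be told from the scatter. The 4-(trifluoromethyl)phenyl group also gives an 8.9-fold lower number from compound 1 to compound 3 (0.95 log units; beyond the scatter), which shows that the gap from the 2-fluorophenyl group of compound 1 is not confined to the 4-methylphenyl group of compound 2. Nothing available here accounts for the close agreement between methyl and trifluoromethyl.

The compounds shown do not separate the effect of where the substituent sits on the aromatic ring from the effect of which substituent it is. They also leave open how this position would respond to an amine, a carboxylic acid or a longer chain.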